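A Fused Indole Replaces the Brominated Thiophene

The compounds below may be only part of what the source reports. "The series", "measured", "known", "first", "only" and "open" are said of these compounds alone.

Three measured compounds share one core and differ only in the aromatic group at the far end of an unsaturated amide chain. Compound 1 `O=C(/C=C/c1ncc2ccccc2n1)Nc1ccc2ncnc(Nc3cccc(Cl)c3)c2c1` carries a quinazolin-2-yl group, compound 2 `O=C(/C=C/c1cccs1)Nc1ccc2ncnc(Nc3cccc(Cl)c3)c2c1` a thiophen-2-yl group, and compound 3 `O=C(/C=C/c1ccc(Br)s1)Nc1ccc2ncnc(Nc3cccc(Cl)c3)c2c1` a 5-bromothiophen-2-yl group. In a functional assay on A549 cells (Homo sapiens) for antiproliferative activity, read by MTT assay, with a stated time of 48 h (a higher number here means a weaker inhibitor, a lower number a stronger inhibitor), compound 1 gives 3350 nM, compound 2 gives 9310 nM, and compound 3 gives 1580 nM. Compound 3 therefore has the lowest number of the three, with a 2.1-fold lower number from compound 1 to compound 3 (0.33 log units; beyond the scatter) and a 5.9-fold lower number from compound 2 to compound 3 (0.77 log units; beyond the scatter).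

Compound 4 `O=C(/C=C/c1c[nH]c2ccccc12)Nc1ccc2ncnc(Nc3cccc(Cl)c3)c2c1` differs from compound 3 in one place: 1H-indol-3-yl in place of 5-bromothiophen-2-yl on a double-bonded chain carbon bound to a double-bonded chain carbon. Among the compounds with values here, two measured steps bear on this change. The bromine alone accounted for a 5.9-fold lower number from compound 2 to compound 3 (0.77 log units; beyond the scatter), and the indole carries no bromine, which points toward a higher number. Exchanging a single five-membered ring for a fused two-ring group resembles the contrast between compound 1 and compound 3, where a 2.1-fold lower number from compound 1 to compound 3 (0.33 log units; beyond the scatter) was observed, and compound 1 already holds a fused two-ring group. Taken together, compound 4 is expected to show a modest upward step of a 1.9-fold higher number from compound 3 to compound 4 (0.28 log units; within the scatter). Compound 4 is therefore estimated at 3000 nM in this assay, with a plausible range from 1000 nM to 9000 nM.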

Compound 4, half-maximal inhibitory concentration: 3670 nM
Compound 4: middle estimate off by 1.2-fold (0.09 log units), on the low side; measured number inside the range.
By their numbers in this assay, from the lowest: compound 3; then compounds 1 and 4 (each within the scatter of the next); then compound 2.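

In this assay, the fused 1H-indol-3-yl group does not match the brominated thiophene (a 2.3-fold higher number from compound 3 to compound 4 (0.37 log units; beyond the scatter)), yet it gives a lower number than the plain thiophene (a 2.5-fold lower number from compound 2 to compound 4 (0.40 log units; beyond the scatter)). It also sits level with the other fused group (a 1.1-fold higher number from compound 1 to compound 4 (0.04 log units; within the scatter)), so among these four compounds both fused two-ring groups fall between the two thiophenes, and swapping quinazolin-2-yl for 1H-indol-3-yl makes no measurable difference at this position, even though the indole brings a hydrogen-bond donor that quinazolin-2-yl lacks. Nothing in the available data explains why the four end groups fall in this order.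

The compounds shown leave open whether adding a bromo to the 1H-indol-3-yl group would lower the number as it did on the thiophene, and whether a methyl on the indole nitrogen would change the result. They also leave open how a plain phenyl ring, or an end group carrying an amine or a carboxylic acid, would compare at this position on the chain.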